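This account rests on a few compounds, and the source may have more. Where it says the series, first, only, none or still open, it means among the compounds named here.

Compound 1 `Cc1ccc(-c2nnc(-c3cc4ccccc4nc3C)o2)cc1` is the weakest inhibitor in an ADME assay on A549 cells (Homo sapiens) for cytotoxicity, read by MTT assay, with a stated time of 48 h (a higher number here means a weaker inhibitor, a lower number a stronger inhibitor), where compound 1 gives 175 ug/mL, the highest of the three numbers. Compound 3 `Cc1nc2ccccc2cc1-c1nnc(-c2ccccc2C(=O)O)o1` gives 106 ug/mL and compound 2 `Cc1nc2ccccc2cc1-c1nnc(-c2ccc(OC(F)(F)F)cc2)o1` gives 91.1 ug/mL, both within the scatter of compound 1. Among the compounds with values here, the one measured step, a 1.9-fold lower number from compound 1 to compound 2 (0.28 log units; within the scatter), changes a substituent on the same aryl ring and lies within the scatter. Compound 4 `CCCCCc1nnc(-c2cc3ccccc3nc2C)o1` differs from compound 1 by pentyl in place of 4-methylphenyl on an aromatic carbon. Within the data shown here, no measured step exchanges that aryl ring for a chain, so only the flat step from compound 1 to compound 2 offers guidance, and a step of no more than the scatter is expected, a 1.2-fold lower number from compound 1 to compound 4 (0.07 log units; within the scatter). Compound 4 is therefore estimated at 150 ug/mL, in a range from 70 ug/mL to 320 ug/mL.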

Compound 4, half-maximal inhibitory concentration: 72.2 ug/mL
Compound 4: the middle estimate sits 2.1-fold (0.32 log units) above what was measured, within the range that was stated.
By their numbers in this assay, from the lowest: compounds 4, 2, 3 and 1 (each within the scatter of the next, the first and the last beyond it).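

Within the data shown here, exchanging the 4-methylphenyl for pentyl at this position gives the first step beyond the scatter in this assay (a 2.4-fold lower number from compound 1 to compound 4 (0.38 log units; beyond the scatter)), although it is modest. The aromatic ring on this carbon is therefore not required to reach the lower number, and an open chain without a ring goes with a larger change than the one seen within the aryl series. Nothing available explains this step. The compounds shown leave open whether a shorter or longer chain would move the number further. They also leave open how a chain ending in an amine or a carboxylic acid would behave here.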